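Removing the cyano group from compound 1

The source may hold more compounds than are shown below. What is called first, only, known or untested is meant among the compounds shown, and "the series" means these compounds.

For the measured compounds named here, in a physicochemical assay for lipophilicity (on this read-out lower numbers stand for lower lipophilicity and higher numbers for higher lipophilicity), compound 1 `CC(C)OC[C@H](Oc1ncnc2c1cnn2-c1ccccc1Cl)C(=O)Nc1ccc(C#N)cn1` reads 3.5 and stands highest of the three numbers measured so far. Compound 2 `CC(C)OC[C@H](Oc1ncnc2c1cnn2-c1ncccc1Cl)C(=O)Nc1ccc(C#N)cn1` gives 2.5 and compound 3 `CCOC[C@H](Oc1ncnc2c1cnn2-c1ncccc1Cl)C(=O)Nc1cnc(C)cn1` gives 1.8 on the same scale.

Compound 4 `CC(C)OC[C@H](Oc1ncnc2c1cnn2-c1ccccc1Cl)C(=O)Nc1ccccn1` departs from compound 1 in one place hydrogen in place of cyano on an aromatic carbon so that hydrogen stands in place of cyano on an aromatic carbon, and 5-cyanopyridin-2-yl becomes pyridin-2-yl.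

Going by the values given here, only one measured step changes a single place, and it runs a number 1.00 log units lower from compound 1 to compound 2 (beyond the scatter) with 3-chloropyridin-2-yl in place of 2-chlorophenyl on an aromatic nitrogen. That step lies elsewhere in the molecule and removes no cyano group, so it bears only loosely on this change. It shows how far one aromatic swap has moved these numbers but gives no direction for the new step. The expectation therefore starts from compound 1 at 3.5 and allows for a slight rise at most. The expected change is a number 0.10 log units higher from compound 1 to compound 4 (within the scatter) and no shift beyond the scatter is anticipated. The estimate for compound 4 is an expected 3.6 within a range from 3.1 to 4.1 on this scale.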

Compound 4, distribution coefficient: 3.5
Beside the measured number, compound 4's estimate is 0.10 log units above it; the range from low to high includes it.
By their numbers in this assay, from the lowest: compound 3; then compound 2; then compounds 1 and 4 (each within the scatter of the next).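

In this assay, for the compounds shown here, the exchange of 5-cyanopyridin-2-yl for pyridin-2-yl reads no change at the digits printed from compound 1 to compound 4 (within the scatter) and gives the first measured step at this position, on the aromatic carbon para to a large group. Going by these compounds alone, the cyano group leaves with its 2 heavy atoms and 1 hydrogen-bond acceptor, yet the number stays within the scatter, whereas the only earlier single-place step, elsewhere in the molecule, reads a number 1.00 log units lower from compound 1 to compound 2 (beyond the scatter) and so lies beyond it. No measurement shown accounts for why the number holds when the cyano group goes.

This rests on a single pair, so the compounds shown leave open whether the same exchange would read alike with the 3-chloropyridin-2-yl group of compound 2 in place of the 2-chlorophenyl group of compound 1. They also leave open how the number would respond to other groups at this carbon, such as an amine, a carboxylic acid or a longer chain, since only cyano and hydrogen have been compared there.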